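Aminopyrimidine nitriles: alkyl replaces methoxyethoxy at the chain

This account rests on a few compounds, and the source may have more. Where it says the series, first, only, none or still open, it means among the compounds named here.

Measured compounds:
- compound 1 `N#Cc1c(N)n(Cc2ccccc2)c2ncnc(N)c12`: 34000 nM
- compound 2 `Cc1ccc(Cn2c(N)c(C#N)c3c(N)ncnc32)cc1`: > 100000 nM
- compound 3 `COCCOCn1c(N)c(C#N)c2c(N)ncnc21`: 210000 nM

In a functional assay on KB cells (Homo sapiens) for inhibition (on this read-out lower numbers stand for stronger inhibition and higher numbers for weaker inhibition), compound 1 gives 34000 nM. Compound 2 reaches only a limit of the assay, > 100000 nM (the limit of > 100000 nM in this assay, at which 1 of the 3 values shown sits). Compound 3 gives 210000 nM, the highest of the two numbers; its nearest neighbour is compound 1, with a 6.2-fold higher number from compound 1 to compound 3 (0.79 log units; beyond the scatter). The step that the limit leaves unreadable from compound 2 to compound 3 cannot be read because of the limit.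

Compound 4 `CCCn1c(N)c(C#N)c2c(N)ncnc21` is not yet measured. It differs from compound 3 by ethyl in place of 2-methoxyethoxy on a saturated chain carbon bound to an aromatic nitrogen. Among the compounds with values here, the only readable step at the same place is a 6.2-fold higher number from compound 1 to compound 3 (0.79 log units; beyond the scatter), where the 2-methoxyethoxy group sat on the higher-number side; compound 4 removes that group but brings in ethyl rather than phenyl, so that step is only a partial guide, and an at least 2.9-fold higher number from compound 1 to compound 2 (0.46 log units; beyond the scatter) concerns a different place.

The step from compound 3 to compound 4 is therefore expected to be small, possibly a lower number but within or near the scatter: a 1.4-fold lower number from compound 3 to compound 4 (0.15 log units; within the scatter). Compound 4 is expected to give about 150000 nM, with a range from 50000 nM to 400000 nM.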

Compound 4, half-maximal inhibitory concentration: 15000 nM
The estimate for compound 4 lay 10-fold (1.00 log units) above the measured number; measured number outside the range, below it.
By their numbers in this assay, from the lowest: compound 4; then compound 1; then compound 3.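

In this assay, within the data shown here, the largest readable change at this place is ethyl in place of 2-methoxyethoxy, a 14-fold lower number from compound 3 to compound 4 (1.15 log units; beyond the scatter), so the group on the saturated chain carbon bound to an aromatic nitrogen can shift the number further than the earlier steps showed. An aromatic group is not required there for the lowest number in this short set: ethyl in place of phenyl gives a 2.3-fold lower number from compound 1 to compound 4 (0.36 log units; beyond the scatter). Ethyl in place of 4-methylphenyl gives an at least 6.6-fold lower number from compound 2 to compound 4 (0.82 log units; beyond the scatter), a step whose size is open-ended since compound 2 carries only a limit: the limit of > 100000 nM in this assay, at which 1 of the 4 values shown sits.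

On these data alone, whether a longer chain such as butyl, or a propyl chain ending in an amine, would keep a number this low remains open. Nothing shown separates the effect of chain length from the loss of the oxygen atoms of 2-methoxyethoxy.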